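Shortening the Alkyne Chain of a Xanthine Ester

This account rests on a few compounds, and the source may have more. Where it says the series, first, only, none or still open, it means among the compounds named here.

Measured compounds:
Compound 1 `C#CCCCOC(=O)Cn1cnc2c1c(=O)n(C)c(=O)n2C` — 36600 nM in a functional assay on HT-29 cells (Homo sapiens) for cytotoxicity, read by MTT assay, with a stated time of 48 h; a higher number here means a weaker inhibitor, a lower number a stronger inhibitor
Compound 2 `CCn1c(=O)ccn(C2OC(Cn3cc(COC(=O)C(C)NC(=O)C(C)n4cnc5c4c(=O)n(C)c(=O)n5C)nn3)C(O)C2O)c1=O` — 2710 nM in this assay
Compound 3 `CCn1c(=O)ccn(C2OC(Cn3cc(COC(=O)CNC(=O)Cn4cnc5c4c(=O)n(C)c(=O)n5C)nn3)C(O)C2O)c1=O` — 2900 nM in this assay

Compound 1 stands at the highest of the three numbers in this assay, so it is the weakest inhibitor of the set. Compound 3 lies closest to it, a gap beyond the scatter, and compound 2 lies furthest, also beyond the scatter. Compounds 2 and 3 sit within the scatter of each other, so no order between them can be read.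

The step of interest leads from compound 1 to compound 4 `C#CCCOC(=O)Cn1cnc2c1c(=O)n(C)c(=O)n2C`, which has not yet been measured in this assay. The difference is ethynyl in place of propargyl on a saturated chain carbon, two bonds along the chain from an oxygen next to a carbonyl group. Only the length of the saturated chain carrying the terminal triple bond changes; the shared core and the ester linkage stay as they are. For the measured compounds named here, no measured pair in the set shows the effect of such a chain shortening, so there is no precedent to lean on. The expectation is for a step of about a 1.1-fold higher number from compound 1 to compound 4 (0.04 log units; within the scatter), that is, nothing beyond the scatter in either direction. Compound 4 is therefore estimated at 40000 nM, within a range from 15000 nM to 110000 nM.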

Compound 4, half-maximal inhibitory concentration: 152000 nM
Estimate against measurement, compound 4: 3.8-fold (0.58 log units) below, and the stated range ends below it.
By their numbers in this assay, from the lowest: compounds 2 and 3 (each within the scatter of the next); then compound 1; then compound 4.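

In this assay, the chain carrying the terminal triple bond turns out to be a position where a small change registers: ethynyl in place of propargyl on a saturated chain carbon, two bonds along the chain from an oxygen next to a carbonyl group, gives a 4.2-fold higher number from compound 1 to compound 4 (0.62 log units; beyond the scatter), a modest step but one beyond the scatter. For the compounds shown here, the earlier compounds formed no pair differing in one place, so this is the first reading of any single change in the set, and it shows that shortening pent-4-yn-1-yl to but-3-yn-1-yl, with the ester linkage and the shared core untouched, is enough on its own to move the number towards weaker inhibition. Nothing available bears on why the shorter chain reads this way.

The compounds shown leave open how a longer chain, a plain saturated chain without the triple bond, or a chain ending in an amine would read in this assay. A single step also cannot say whether the number follows chain length steadily in either direction.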